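Replacing a dichlorophenoxy group with a fluorophenoxy group

The source may report more compounds than this note shows. Statements on the series, on what has been measured and on what is new or still open speak of the compounds shown alone.

Compound 1 `Nc1cc(N)c2nc(-c3ccccc3)c(Oc3ccc(Cl)c(Cl)c3)nc2c1` and compound 2 `COc1cc(CNc2nc3cc(N)cc(N)c3nc2-c2ccccc2)cc(OC)c1OC` share a common core carrying two amino groups and a phenyl group, and differ in what is attached at the remaining position. In a functional assay on SK-MEL-28 cells (Homo sapiens) for inhibition, read by sulforhodamine B assay, with a stated time of 48 h (on this read-out higher numbers stand for weaker inhibition of growth and lower numbers for stronger inhibition of growth), compound 1 gives 21400 nM, the higher of the two numbers recorded; in this assay compound 2 gives 8510 nM, a gap that lies beyond the usual scatter of repeated measurements.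

Compound 3 `Nc1cc(N)c2nc(-c3ccccc3)c(Oc3ccc(F)cc3)nc2c1` has not yet been measured. It differs from compound 1 in a single place: 4-fluorophenyl in place of 3,4-dichlorophenyl on an oxygen on an aromatic ring. Going by the values given here, no measured pair of compounds isolates this particular exchange, so nothing in the data shows how this assay responds to it. On these data alone, with compound 1 already a weak inhibitor of growth at 21400 nM, the exchange is expected to shift the number by no more than a modest amount, and the direction remains open. The estimate for compound 3 in this assay is 25000 nM, within a range from 8000 nM to 80000 nM, which corresponds to an expected step of a 1.2-fold higher number from compound 1 to compound 3 (0.07 log units; within the scatter).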

Compound 3, concentration for 50% growth inhibition: 19500 nM
Compound 3: middle estimate off by 1.3-fold (0.11 log units), on the high side; low and high end bracket the measured number.
By their numbers in this assay, from the lowest: compound 2; then compounds 3 and 1 (each within the scatter of the next).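

In this assay the exchange of 3,4-dichlorophenyl for 4-fluorophenyl on an oxygen on an aromatic ring gives a 1.1-fold lower number from compound 1 to compound 3 (0.04 log units; within the scatter) and so stays within the usual scatter of repeated measurements. Going by these compounds alone, this is the first measured pair that isolates a change at this position, and it shows that the read-out does not separate these two groups, even though the group that enters carries one fluorine and the group that leaves carries two chlorines. No available evidence bears on why the two groups read alike.

Within the data shown here, the pair covers only two halogen-bearing phenyl groups on that oxygen, so it remains open whether a phenyl group carrying a nitrile or a carboxylic acid would give a number outside the scatter of these two. On these data alone, it also remains open whether a morpholine or a longer alkyl chain in place of the whole 4-fluorophenoxy group would move the number in either direction, since this single step says nothing about groups of other kinds at this place.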